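The compounds below may be only part of what the source reports. "The series", "measured", "known", "first", "only" and "open" are said of these compounds alone.

In an ADME assay on Vero cells (Chlorocebus sabaeus) for cytotoxicity, read by resazurin assay, with a stated time of 3 days (on this read-out lower numbers stand for stronger inhibition and higher numbers for weaker inhibition), compound 2 `CCN(CC)c1cc2[nH]c(C3CCCCC3)nc2cc1NC(=O)OCC(F)(F)F` gives > 100 ug/mL, which is a limit of the assay and not a number. Compound 1 `O=C(Nc1cc2nc(C3CCCCC3)[nH]c2cc1N1CCCC1)OCC(F)(F)F` likewise gives > 100 ug/mL, a limit. Compound 3 `CN(C)c1cc2[nH]c(C3CCCCC3)nc2cc1NC(=O)c1ccco1` gives > 100 ug/mL, again a limit. The step that the two limits leave unreadable from compound 1 to compound 2 cannot be sized, since (the limit of > 100 ug/mL in this assay, at which 3 of the 3 values shown sit). Compound 4 `CCN(CC)c1cc2[nH]c(C3CCCCC3)nc2cc1NC(=O)c1ccc(OC(F)(F)F)cc1` has not yet been measured; it differs from compound 2 by 4-(trifluoromethoxy)phenyl in place of 2,2,2-trifluoroethoxy on a carbonyl carbon. Among the compounds with values here, no measured step bears on this change, so no direction can be read from the measured compounds, and nothing among them points to a step beyond the scatter. The estimate for compound 4 is 100 ug/mL, with a range from 40 ug/mL to 200 ug/mL. That estimate means an expected step of a number no higher from compound 2 to compound 4 (the limit leaves the size open), most likely ending at the same limit.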

Compound 4, half-maximal inhibitory concentration: > 100 ug/mL
Compound 4: only a limit was reported; the forecaster's own chance of this, stated with the estimate: 60%; the middle value lies on the limit itself.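

No step can be read from compound 2 to compound 4, since both stop at a limit of the assay: the limit of > 100 ug/mL in this assay, at which 4 of the 4 values shown sit. The compounds shown leave open how far beyond that limit each lies, and so whether this swap of groups makes any difference in this assay.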